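This account rests on a few compounds, and the source may have more. Where it says the series, first, only, none or still open, it means among the compounds named here.

Working notes on the series.

Within the data shown here, compound 1, `COc1ccccc1-c1n[nH]cc1N1CCCNCC1`, is the first member of the set. In an assay on isolated protein for binding affinity to 5-hydroxytryptamine receptor 1D (Homo sapiens) (a lower number here means a stronger inhibitor, a higher number a weaker inhibitor), compound 1 gives > 10000 nM, which is a limit of the assay rather than a number. Compound 2, `c1ccc(-c2n[nH]cc2N2CCCNCC2)cc1`, differs from compound 1 by hydrogen in place of methoxy on an aromatic carbon. In this assay compound 2 gives > 10000 nM, again a limit. The step from compound 1 to compound 2 is therefore a step that the two limits leave unreadable from compound 1 to compound 2; both values sit at the limit of > 10000 nM in this assay, at which 3 of the 3 values shown sit, so nothing about the size of this step can be read.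

Compound 3, `COc1ccc(-c2n[nH]cc2N2CCNCC2)cc1`, carries a different core; the difference between the core of compound 3 and the core of compound 1 is not broken down here. In this assay compound 3 gives > 10000 nM, also a limit.

Compound 4, `c1ccc(-c2n[nH]cc2N2CCNCC2)cc1`, is not yet measured. It differs from compound 3 by hydrogen in place of methoxy on an aromatic carbon. This is the same kind of change as that from compound 1 to compound 2, not the same change: in compound 1 the methoxy sits ortho to a large group, in compound 3 it sits para to a large group.

For compound 4 a step that the limit leaves unreadable from compound 3 to compound 4 is expected in this assay; this rests on compound 3 giving > 10000 nM and on (the limit of > 10000 nM in this assay, at which 3 of the 3 values shown sit), where all three measured values sit, so that the earlier step that the two limits leave unreadable from compound 1 to compound 2 offers no readable size to lean on. Compound 4 is expected to give about 15000 nM, estimated between 5000 nM and 50000 nM.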

Compound 4, inhibition constant: > 10000 nM
Compound 4: no number, only a limit (the forecaster's own chance of this, stated with the estimate: 85%); the middle value lies beyond the limit too.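

In this assay compound 4 gives > 10000 nM, which is a limit of the assay and not a number. The step between compound 3 and compound 4 cannot be read, since both compounds sit at the same limit: the limit of > 10000 nM in this assay, at which 4 of the 4 values shown sit.

The compounds shown leave open what size of effect, if any, the methoxy or the difference between the cores has on the value in this assay.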